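One Methyl Fewer on a Compound at the Limit

The source may report more compounds than this note shows. Statements on the series, on what has been measured and on what is new or still open speak of the compounds shown alone.

In a functional assay on Malme-3M cells (Homo sapiens) for cytotoxicity, read by MTT assay, with a stated time of 6 days (on this read-out higher numbers stand for an effect only at larger amounts of compound and lower numbers for an effect already at smaller amounts), compound 1 `COC(=O)c1c(-c2ccc(O)cc2)oc2cc(OC)ccc2c1=O` gives 20.1 ug/mL. Compound 2 `COc1cc(-c2cc(=O)c3cc(O)ccc3o2)cc(OC)c1OC` is reported as > 25 ug/mL, and this is a limit of the assay, not a number. Compound 3 `COc1cc(-c2cc(=O)c3cc(O)ccc3o2)cc(OC)c1O` differs from compound 2 in one place: hydrogen in place of methyl on an oxygen on an aromatic ring. This puts hydrogen in place of methyl on an oxygen on an aromatic ring, so a methoxy becomes a hydroxy. Among the measured compounds shown here, no pair of measured compounds here shows what such a change does in this assay, so the expectation stays modest: a step within the usual scatter, leaning slightly towards an effect at smaller amounts. The expected move is an at least 1.2-fold lower number from compound 2 to compound 3 (0.09 log units; that floor lies within the scatter). The assay may again report only a limit. For compound 3 the estimated value is 20 ug/mL, with an expected range from 9 ug/mL to 32 ug/mL.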

Compound 3, concentration for half-maximal effect: > 25 ug/mL
Compound 3 ended at the assay's limit (the forecaster's own chance of this, stated with the estimate: 45%); middle value at least 1.2-fold (0.09 log units) from the limit.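

Compound 2 and compound 3 both end at a limit of the assay rather than at a number, so no step between them can be read: the limit of > 25 ug/mL in this assay, at which 2 of the 3 values shown sit.

The compounds shown leave open whether going from methoxy to hydroxy here changes the effect at all, and if so, in which direction and by how much.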